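The source may report more compounds than this note shows. Statements on the series, on what has been measured and on what is new or still open speak of the compounds shown alone.

Measured compounds:
compound 1 `C[C@H](Nc1c(C(=O)NCc2ccc(F)cc2)nc(Br)c2cccnc12)c1ccccc1`: "not determined" (no result reported) in a toxicity assay on C8166 cells (Homo sapiens) for cytotoxicity, read by MTT assay, with a stated time of 72 h; on this read-out higher numbers stand for lower toxicity in this test and lower numbers for higher toxicity in this test
compound 2 `NCCCNc1c(C(=O)NCc2ccc(F)cc2)nc(Br)c2cccnc12`: "not determined" (no result reported) in this assay
compound 3 `Cc1ccc(S(=O)(=O)Oc2c(C(=O)NCc3ccc(F)cc3)nc(Br)c3cccnc23)cc1`: 31000 nM in this assay

For the measured compounds named here, compound 3 stands alone on the numbers: it is the only compound of the three with a value in this assay, since compound 1 and compound 2 carry no result there. Going by the values given here, nothing can therefore be said about how any pair of measured compounds compares, and no step between measured compounds is available to set a scale for the change now considered.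

Compound 4 `O=C(NCc1ccc(F)cc1)c1nc(Br)c2cccnc2c1NCCO` is the next entry to be measured in this assay. It differs from compound 3 in one place: (2-hydroxyethyl)amino in place of ((4-methylphenyl)sulfonyl)oxy on an aromatic carbon.

Among the compounds with values here, with only one number in hand, the step is judged from the structural change alone. The change exchanges a larger, ring-bearing substituent for a short chain carrying two hydrogen-bond donors. No reason from the data points to a sharp rise in toxicity, and the expectation is a step that stays within the usual scatter or leans toward lower toxicity. The step expected from compound 3 is a 1.5-fold higher number from compound 3 to compound 4 (0.16 log units; within the scatter), stated as an estimate, not a measurement.

For compound 4 the estimated half-maximal cytotoxic concentration in this assay is 45000 nM, with a range from 12000 nM to 170000 nM, and some chance that only a limit is reported.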

Compound 4, half-maximal cytotoxic concentration: 232000 nM
Compound 4: middle estimate off by 5.2-fold (0.71 log units), on the low side, outside the stated range (above it).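

In this assay, for the compounds shown here, placing (2-hydroxyethyl)amino in place of ((4-methylphenyl)sulfonyl)oxy on the aromatic carbon para to a bromo group gives a 7.5-fold higher number from compound 3 to compound 4 (0.87 log units; beyond the scatter), the only step that can be read so far. This shows that the read-out at this position responds to the substituent it carries, with the change here moving toward lower toxicity in this test, although a single pair cannot show how general that is. The exchange removes a six-membered aromatic ring of carbon only, goes from 11 heavy atoms to 4, and brings in hydrogen-bond donors all at once, and no measurement available here bears on which of these differences accounts for the step.

Steps involving compound 1 and compound 2 cannot be read, so the amine-linked substituents at this position rest on compound 4 alone. Still open, going by these compounds, is what a plain ethylamino group without the hydroxyl, a longer hydroxyalkylamino chain, or a terminal carboxylic acid on the chain would give at this position.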